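Benzyl against phenyl on the amide nitrogen of a thiazole inhibitor

This account rests on a few compounds, and the source may have more. Where it says the series, first, only, none or still open, it means among the compounds named here.

Of the compounds shown here, two sharing one core have been measured in an assay on isolated protein for inhibition of ubiquitin carboxyl-terminal hydrolase 7 (Homo sapiens), read by fluorescence, with stated times of 30 min and 3 h; a lower number here means a stronger inhibitor, a higher number a weaker inhibitor. Compound 1 `O=C(NCc1cccc(F)c1)c1nc([N+](=O)[O-])c(Sc2c(Cl)cncc2Cl)s1` carries a 3-fluorobenzyl group on the amide nitrogen and gives 1350 nM. For the measured compounds named here, compound 2 `O=C(Nc1ccccc1)c1nc([N+](=O)[O-])c(Sc2c(Cl)cncc2Cl)s1` carries a phenyl group at the same nitrogen and gives 40500 nM, the highest of the two numbers; the only measured step, a 30-fold higher number from compound 1 to compound 2 (1.48 log units; beyond the scatter), lies well beyond the scatter.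

Compound 3 `O=C(NCc1ccccc1)c1nc([N+](=O)[O-])c(Sc2c(Cl)cncc2Cl)s1` differs from compound 2 by a single change: benzyl in place of phenyl on an amide-type nitrogen. The step from compound 1 to compound 2 bears directly on this change, since it replaced a benzyl-type group by a phenyl and raised the number strongly; compound 3 simply reverses that in kind, lacking only the fluorine of compound 1. A large fall in this assay is therefore expected, of a size close to that step. Compound 3 is expected to land near 2000 nM, within 700 nM to 6000 nM, which amounts to an expected step of a 20-fold lower number from compound 2 to compound 3 (1.31 log units; beyond the scatter).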

Compound 3, half-maximal inhibitory concentration: 4210 nM
For compound 3 the middle estimate is 2.1-fold (0.32 log units) below the measured one; low and high end bracket the measured number.
By their numbers in this assay, from the lowest: compound 1; then compound 3; then compound 2.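

The earlier pair changed the group on the amide nitrogen in a way that left two differences bound together, the fluorine and the link between ring and nitrogen, and compound 3 separates them. In this assay, benzyl in place of phenyl on the amide-type nitrogen gives a 9.6-fold lower number from compound 2 to compound 3 (0.98 log units; beyond the scatter), so the benzyl group accounts for much of the earlier difference even without any fluorine on its ring. The fluorine still counts, since hydrogen in place of fluoro on the aromatic carbon gives a 3.1-fold higher number from compound 1 to compound 3 (0.49 log units; beyond the scatter), and the lowest number of the three therefore belongs to compound 1, which carries both features. Nothing available here explains either step.

Going by these compounds, whether a longer chain on the amide nitrogen, such as phenethyl, would lower the number further remains open, as does whether chloro or methoxy in place of fluoro on that aromatic carbon would match the effect of the fluorine. All three compounds also keep the rest of the shared core, so they leave open how these steps would read with an amine in place of the nitro group.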